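This account rests on a few compounds, and the source may have more. Where it says the series, first, only, none or still open, it means among the compounds named here.

Series notes. Compound 1 `CC(C)(C)c1ccc(C(=O)N2CCC3(CC2)C(=O)N(CC(=O)N2CCCC(O)C2)CN3c2ccccc2)cc1` and compound 2 `CC(C)(C)c1ccc(C(=O)N2CCC3(CC2)C(=O)N(CC(=O)NCCCCN)CN3c2ccccc2)cc1` share a core and differ only in the group on the carbonyl carbon of the terminal amide. In an assay on HEK293 cells for displacement of a labelled ligand from NPC1-like intracellular cholesterol transporter 1 (Homo sapiens) (on this read-out higher numbers stand for weaker inhibition and lower numbers for stronger inhibition), compound 1 gives 12200 nM, and in this assay compound 2 gives 14500 nM. Replacing 3-hydroxypiperidin-1-yl by (4-aminobutyl)amino on that carbonyl carbon gave a 1.2-fold higher number from compound 1 to compound 2 (0.08 log units; within the scatter). Within the data shown here, compound 2 thus carries the higher of the two numbers measured so far, but its nearest neighbour, compound 1, sits within the scatter, so no ranking between the two can be read from this assay.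

Compound 3 `CC(C)(C)c1ccc(C(=O)N2CCC3(CC2)C(=O)N(CC(=O)NCCCCCO)CN3c2ccccc2)cc1` differs from compound 2 by hydroxymethyl in place of amino on a saturated chain carbon, four bonds along the chain from an amide-type nitrogen. Among the measured compounds shown here, the only measured step that bears on this end of the molecule is a 1.2-fold higher number from compound 1 to compound 2 (0.08 log units; within the scatter), which stayed within the scatter although it rebuilt the same chain end far more thoroughly than the present exchange does. On that basis, for compound 3 the expected step in this assay is a 1.1-fold lower number from compound 2 to compound 3 (0.05 log units; within the scatter), nothing beyond the scatter. Compound 3 is therefore estimated at 13000 nM in this assay, with a range from 6000 nM to 30000 nM.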

Compound 3, half-maximal inhibitory concentration: 9400 nM
The estimate for compound 3 lay 1.4-fold (0.14 log units) above the measured number; the measured number falls inside the stated range.
By their numbers in this assay, from the lowest: compounds 3, 1 and 2 (each within the scatter of the next).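

In this assay, hydroxymethyl in place of amino on a saturated chain carbon gave a 1.5-fold lower number from compound 2 to compound 3 (0.19 log units; within the scatter) and so left the number within the scatter, even though the chain end changed from amino to hydroxyl. The step of a 1.3-fold lower number from compound 1 to compound 3 (0.11 log units; within the scatter) for (5-hydroxypentyl)amino in place of 3-hydroxypiperidin-1-yl likewise stays within the scatter, so all three groups on this carbonyl carbon, the ring-bearing one and both open chains, now give numbers that cannot be told apart, whether the chain ends in amino or in hydroxyl. No evidence is at hand that would explain this absence of a measurable difference.

Whether any group at this chain end can move the number beyond the scatter remains open, since a carboxylic acid, a dimethylamino group or a much longer or shorter chain lies outside the compounds shown. Also open, as far as these compounds go, is whether changes elsewhere on the shared core would have a larger effect in this assay than the exchanges at this end of the molecule.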